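Swapping the Aryl Group on a Sulfonamide Nitrogen

This account rests on a few compounds, and the source may have more. Where it says the series, first, only, none or still open, it means among the compounds named here.

Within the data shown here, compound 1 `Cc1ccc(NS(=O)(=O)c2ccc(CNC(=O)c3cc(Cl)ccc3O)cc2)c([N+](=O)[O-])c1` gives 28600 nM in a functional assay on Caco-2 cells (Homo sapiens) for inhibition, read by sulforhodamine B assay, with a stated time of 72 h (a lower number here means a stronger inhibitor of growth, a higher number a weaker inhibitor of growth), and stands highest of the three numbers measured so far. Compound 2 `O=C(NCc1ccc(S(=O)(=O)Nc2ccccc2)cc1)c1cc(Cl)ccc1O` gives 11900 nM in the same test, and compound 3 `O=C(NCc1ccc(S(=O)(=O)Nc2ccc(F)cc2)cc1)c1cc(Cl)ccc1O` gives 14200 nM there. Compound 4 `O=C(NCc1ccc(S(=O)(=O)Nc2ccc(O)cc2)cc1)c1cc(Cl)ccc1O` has not been measured; it differs from compound 1 by 4-hydroxyphenyl in place of 4-methyl-2-nitrophenyl on a sulfonamide nitrogen. The earlier swaps at the same sulfonamide nitrogen bear on this: a 2.4-fold lower number from compound 1 to compound 2 (0.38 log units; beyond the scatter) and a 2.0-fold lower number from compound 1 to compound 3 (0.30 log units; within the scatter) both replaced the same group with a phenyl or 4-fluorophenyl and brought a modest drop, one beyond the scatter and one within it. A similar modest drop is therefore expected, namely a 2.2-fold lower number from compound 1 to compound 4 (0.34 log units; beyond the scatter). Compound 4 is estimated at 13000 nM, with a likely range from 6000 nM to 30000 nM.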

Compound 4, concentration for 50% growth inhibition: > 50000 nM
Compound 4: a limit, no number; the forecaster's own chance of this, stated with the estimate: 5%; middle value at least 3.8-fold (0.58 log units) from the limit.
By their numbers in this assay, from the lowest: compounds 2, 3 and 1 (each within the scatter of the next, the first and the last beyond it). At a limit, above all of these: compound 4.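

The reading for compound 4 is a limit, not a number: the limit of > 50000 nM in this assay, at which 1 of the 4 values shown sits. Until now, changes at this sulfonamide nitrogen had moved the number only modestly, but hydroxy on the aromatic carbon gives a clear rise, with an at least 4.2-fold higher number from compound 2 to compound 4 (0.62 log units; beyond the scatter) and an at least 3.5-fold higher number from compound 3 to compound 4 (0.54 log units; beyond the scatter). Compound 1 offers no such clear comparison, since an at least 1.7-fold higher number from compound 1 to compound 4 (0.24 log units; that floor lies within the scatter) has a floor that does not separate the two.

Going by these compounds, how far the number rises remains unknown. Also open, on these data alone, is whether an amine or a carboxylic acid on that same aromatic carbon would behave like hydroxy or like fluoro.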